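A pyridine nitrile in place of methylphenyl

A few compounds are considered here, and "the series" means these few. Any claim that something is new, unique, unknown or untested is made for them only; others in the source may bear on it.

Three compounds with a shared core were tested in a functional assay on HEK293 cells for agonist activity at D(4) dopamine receptor (Homo sapiens), read by FLIPR; on this read-out higher numbers stand for an effect only at larger amounts of compound and lower numbers for an effect already at smaller amounts. Compound 1 `Cc1cccc(NC(=O)CN2CCC(c3nccs3)CC2)c1` gives 1 nM, compound 2 `Cc1cccc(NC(=O)CN2CCC(c3ccc(O)cc3)CC2)c1` gives 70 nM, and compound 3 `Cc1cccc(NC(=O)CN2CCC(c3ccccc3C)CC2)c1` gives 340 nM, the highest number of the three, with the step of a 4.9-fold higher number from compound 2 to compound 3 (0.69 log units; beyond the scatter) and the step of a 340-fold higher number from compound 1 to compound 3 (2.53 log units; beyond the scatter) leading up to it. Compound 4 `Cc1cccc(NC(=O)CN2CCC(c3cccc(C#N)n3)CC2)c1` carries the change (6-cyanopyridin-2-yl in place of 2-methylphenyl on a saturated ring carbon). The step of a 340-fold higher number from compound 1 to compound 3 (2.53 log units; beyond the scatter) shows how far a group with hetero atoms can lower the number on this core, while a 4.9-fold higher number from compound 2 to compound 3 (0.69 log units; beyond the scatter) is smaller. Among the compounds with values here, because of a 340-fold higher number from compound 1 to compound 3 (2.53 log units; beyond the scatter) a large step toward a lower number is expected for compound 4, though the nitrile has no measured precedent, so compound 4 is estimated at 20 nM, between 3 nM and 150 nM, a step of a 17-fold lower number from compound 3 to compound 4 (1.23 log units; beyond the scatter).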

Compound 4, half-maximal effective concentration: 36 nM
Estimate against measurement, compound 4: 1.8-fold (0.26 log units) below, and the stated range covers the measured number.
By their numbers in this assay, from the lowest: compound 1; then compounds 4 and 2 (each within the scatter of the next); then compound 3.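

Putting 6-cyanopyridin-2-yl in place of 2-methylphenyl, with hydrogen-bond acceptors entering where there were none, gives a 9.4-fold lower number from compound 3 to compound 4 (0.98 log units; beyond the scatter), so a six-membered aromatic ring at this position need not carry the highest number. The new group and 4-hydroxyphenyl cannot be told apart, as a 1.9-fold lower number from compound 2 to compound 4 (0.29 log units; within the scatter) shows, while a 36-fold higher number from compound 1 to compound 4 (1.56 log units; beyond the scatter) leaves 1,3-thiazol-2-yl clearly lowest of these two. No measurement here explains these steps. Going by these compounds, whether the ring nitrogen or the nitrile carries the drop stays open, and a plain pyridin-2-yl would separate them. On these data alone, how an amine or a carboxylic acid on the ring would read is also open.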